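Reversing the chalcone and swapping methoxy for chlorine

A few compounds are considered here, and "the series" means these few. Any claim that something is new, unique, unknown or untested is made for them only; others in the source may bear on it.

Compound 1 `COc1ccc(C(=O)/C=C/c2cc(-c3ccc(OC)c(OC)c3)n3nc(-c4ccccc4)cc3n2)cc1OC` gives 7200 nM in a functional assay on DU-145 cells (Homo sapiens) for antiproliferative activity, read by MTT assay, with a stated time of 24 h; a lower number here means a stronger inhibitor, a higher number a weaker inhibitor; compound 2 `COc1ccc(C(=O)/C=C/c2cc(-c3ccc(OC)c(OC)c3)n3nc(-c4ccccc4)cc3n2)cc1` gives 14600 nM; compound 3 `COc1ccc(-c2cc(/C=C/C(=O)c3ccccc3)nc3cc(-c4ccccc4)nn23)cc1` gives 13700 nM.

Compound 2 has the highest number of the three, though its gap to compound 3 lies within the scatter; only compound 1 sits clearly lower, the step of a 2.0-fold higher number from compound 1 to compound 2 (0.31 log units; beyond the scatter) being modest. Compound 4 `COc1ccc(-c2cc(C(=O)/C=C/c3ccc(Cl)cc3)nc3cc(-c4ccccc4)nn23)cc1OC` differs from compound 2 by (2-(4-chlorophenyl)ethenyl)carbonyl in place of 2-((4-methoxyphenyl)carbonyl)ethenyl on an aromatic carbon. For the measured compounds named here, no measured step matches this change: the one step known concerns a methoxy on the chalcone ring, not a reversal of the chalcone or a chlorine. Compound 2 and compound 3 show that reversing the chalcone alongside other changes leaves the number about the same. Compound 4 is therefore expected to stay near compound 2, with a step of a 1.3-fold lower number from compound 2 to compound 4 (0.12 log units; within the scatter), estimated at 11000 nM within 4500 nM to 27000 nM.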

Compound 4, half-maximal inhibitory concentration: 22400 nM
Compound 4: middle estimate off by 2.0-fold (0.31 log units), on the low side; the measured number falls inside the stated range.
By their numbers in this assay, from the lowest: compounds 1, 3, 2 and 4 (each within the scatter of the next, the first and the last beyond it).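

In this assay, placing (2-(4-chlorophenyl)ethenyl)carbonyl on this aromatic carbon instead of 2-((4-methoxyphenyl)carbonyl)ethenyl gives a result (a 1.5-fold higher number from compound 2 to compound 4 (0.19 log units; within the scatter)). This position therefore takes the reversed chalcone carrying chlorine with no change that stands clear of the scatter, which the earlier methoxy step could not show. No measured evidence here bears on this result.

On these data alone, the swap reverses the chain and exchanges the ring's group together, so the separate contribution of each stays open. As far as these compounds go, how an amine or a carboxylic acid on that ring would compare also stays open.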